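The compounds below may be only part of what the source reports. "The series", "measured", "known", "first", "only" and "open" are said of these compounds alone.

The series shares one core, carrying an amide with a trifluoromethyl-substituted benzene and a variable group on the aromatic nitrogen, and was tested in an assay on CHO cells for displacement of a labelled ligand from adenosine receptor A1 (Homo sapiens), read by scintillation counting, with a stated time of 3 h; a higher number here means a weaker inhibitor, a lower number a stronger inhibitor. Compound 1 `Cn1cc2c(Cl)nc(NC(=O)c3ccc(C(F)(F)F)cc3)nc2n1` returns in this assay only a limit of the assay, > 100000 nM. Compound 2 `CC(C)(C)Cn1cc2c(Cl)nc(NC(=O)c3ccc(C(F)(F)F)cc3)nc2n1` likewise returns only a limit, > 100000 nM. Among the compounds with values here, compound 3 `CC(C)n1cc2c(Cl)nc(NC(=O)c3ccc(C(F)(F)F)cc3)nc2n1` is the one compound with a number, at 13800 nM. Compound 2 thus stands at the limit of > 100000 nM in this assay, at which 2 of the 3 values shown sit, with no number of its own. Among the measured steps, a step that the two limits leave unreadable from compound 1 to compound 2 cannot be read, while an at least 7.2-fold lower number from compound 1 to compound 3 (0.86 log units; beyond the scatter) and an at least 7.2-fold lower number from compound 2 to compound 3 (0.86 log units; beyond the scatter) both run toward a lower number.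

Compound 4 `CCOC(=O)c1nc(NC(=O)c2ccc(C(F)(F)F)cc2)nc2nn(CC(C)(C)C)cc12` keeps the neopentyl group of compound 2 and differs from it in one place: ethoxycarbonyl in place of chloro on an aromatic carbon. Within the data shown here, none of the measured steps touches this aromatic carbon; all three concern the group on the aromatic nitrogen, so none bears directly on the change at hand. Without any measured step at this position, no shift beyond the scatter is expected in either direction. The step is estimated as a number no higher from compound 2 to compound 4 (the limit leaves the size open). For compound 4 the expected value in this assay is 100000 nM, with a range from 20000 nM to 300000 nM, and a limit rather than a number is considered likely.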

Compound 4, inhibition constant: > 100000 nM
Compound 4 was reported as a limit (the forecaster's own chance of this, stated with the estimate: 65%); the middle value sits exactly at the limit.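

Compound 2 and compound 4 both return only a limit in this assay, so no step between them can be read: the limit of > 100000 nM in this assay, at which 3 of the 4 values shown sit.

The compounds shown leave open whether ethoxycarbonyl in place of chloro on this aromatic carbon shifts the number in either direction, with neopentyl or with the isopropyl of compound 3, the only compound with a number.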